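The source may report more compounds than this note shows. Statements on the series, on what has been measured and on what is new or still open speak of the compounds shown alone.

Measured compounds:
compound 1 `COc1cccc2c1c(C(=O)/C=C(\O)C(=O)O)cn2Cc1ccc(F)c(F)c1`: 71000 nM
compound 2 `COc1cccc2c1c(C(=O)/C=C(\O)C(=O)O)cn2Cc1cccc(F)c1F`: 17500 nM
compound 3 `COc1cccc2c1c(C(=O)/C=C(\O)C(=O)O)cn2Cc1cc(F)cc(F)c1`: 29500 nM

In an ADME assay on MT4 cells (Homo sapiens) for cytotoxicity, read by MTT assay (on this read-out lower numbers stand for higher toxicity in this test and higher numbers for lower toxicity in this test), compound 3 holds the second highest of the three numbers. Toward compound 1 the gap is beyond the scatter, as shown by a 2.4-fold lower number from compound 1 to compound 3 (0.38 log units; beyond the scatter); toward compound 2 it is within it, as shown by a 1.7-fold higher number from compound 2 to compound 3 (0.23 log units; within the scatter). Compound 4 `COc1cccc2c1c(C(=O)/C=C(\O)C(=O)O)cn2Cc1ccc(F)cc1` carries 4-fluorophenyl in place of 3,5-difluorophenyl on a saturated chain carbon bound to an aromatic nitrogen. Among the measured compounds shown here, no measured step removes a fluorine; the three isomer swaps gave modest steps at most, the largest being a 4.1-fold lower number from compound 1 to compound 2 (0.61 log units; beyond the scatter). The step is therefore expected to stay small, estimated at a 1.3-fold higher number from compound 3 to compound 4 (0.11 log units; within the scatter), with no clear direction. Compound 4 is expected to give 38000 nM, with a range from 14000 nM to 100000 nM.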

Compound 4, half-maximal cytotoxic concentration: 41100 nM
For compound 4 the middle estimate is 1.1-fold (0.03 log units) below the measured one; measured number inside the range.
By their numbers in this assay, from the lowest: compounds 2, 3, 4 and 1 (each within the scatter of the next, the first and the last beyond it).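

In this assay, removing a fluorine rather than moving one leaves the number within the scatter, a 1.7-fold lower number from compound 1 to compound 4 (0.24 log units; within the scatter), and the swap of 3,5-difluorobenzyl for 4-fluorobenzyl does the same, a 1.4-fold higher number from compound 3 to compound 4 (0.14 log units; within the scatter). Among the compounds shown here, only the step from the 2,3-difluorophenyl group lies beyond the scatter, a 2.3-fold higher number from compound 2 to compound 4 (0.37 log units; beyond the scatter), although compound 3 stays within the scatter of both compound 2 and compound 4. Nothing given here offers a reason for these steps.

The compounds shown leave open whether a plain benzyl without fluorine would stay within this range. They also leave open whether a trifluoromethyl group or an amine on the same phenyl ring would move the number beyond the scatter.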